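A few compounds are considered here, and "the series" means these few. Any claim that something is new, unique, unknown or untested is made for them only; others in the source may bear on it.

Cyanoacrylamides on a shared core, varied only in the aryl group on the double-bonded chain carbon:
compound 1, `COc1ccc(CNC(=O)/C(C#N)=C/c2ccc[nH]2)cc1`
compound 2, `COc1ccc(CNC(=O)/C(C#N)=C/c2ccc(C)o2)cc1`
compound 3, `COc1ccc(CNC(=O)/C(C#N)=C/c2ccc(Br)o2)cc1`

In a functional assay on SMA cells (Homo sapiens) for inhibition, read by MTT assay, with a stated time of 72 h (on this read-out lower numbers stand for stronger inhibition of growth and higher numbers for weaker inhibition of growth), compound 1 reaches only the assay limit, > 50000 nM, so no number is known for it. Compound 2 gives 69000 nM. Compound 3 gives 14000 nM and so holds the lowest of the two numbers shown; the nearest number belongs to compound 2, and the gap, a 4.9-fold lower number from compound 2 to compound 3 (0.69 log units; beyond the scatter), lies beyond the scatter. The limit on compound 1 leaves a step that the limit leaves unreadable from compound 1 to compound 2, while an at least 3.5-fold lower number from compound 1 to compound 3 (0.55 log units; beyond the scatter) is at least modest.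

Compound 4, `COc1ccc(CNC(=O)/C(C#N)=C/c2ccc(C)cc2)cc1`, differs from compound 3 in one place: 4-methylphenyl in place of 5-bromofuran-2-yl on a double-bonded chain carbon bound to a double-bonded chain carbon. Among the measured compounds shown here, two measured steps bear on this. a 4.9-fold lower number from compound 2 to compound 3 (0.69 log units; beyond the scatter) shows that bromo rather than methyl on the aromatic carbon gave the lower number, and compound 4 returns to a methyl. an at least 3.5-fold lower number from compound 1 to compound 3 (0.55 log units; beyond the scatter) shows that the bromofuran also gave a lower number than the pyrrole. For the measured compounds named here, the move from a five-membered ring with one hetero atom to a six-membered ring of carbon only has no measured counterpart here. Giving up the bromo is expected to undo most of the gain seen in compound 3, so a step of a 3.2-fold higher number from compound 3 to compound 4 (0.51 log units; beyond the scatter) is expected, a modest weakening. Compound 4 is therefore estimated at 45000 nM, expected between 12000 nM and 150000 nM.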

Compound 4, concentration for 50% growth inhibition: 42000 nM
For compound 4 the middle estimate is 1.1-fold (0.03 log units) above the measured one; low and high end bracket the measured number.
By their numbers in this assay, from the lowest: compound 3; then compounds 4 and 2 (each within the scatter of the next).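

Among the compounds shown here, with methyl on the ring in both compounds, a 1.6-fold lower number from compound 2 to compound 4 (0.22 log units; within the scatter) is the first step to exchange a five-membered aromatic ring with 1 hetero atom for a six-membered aromatic ring of carbon only, and on this pair the exchange at the double-bonded chain carbon does not move the number beyond the scatter. Against that, a 3.0-fold higher number from compound 3 to compound 4 (0.48 log units; beyond the scatter) sets compound 3 apart from 4-methylphenyl as well as from 5-methylfuran-2-yl, so among the readable values in this small set only 5-bromofuran-2-yl stands out, and the ring change alone does not reproduce its value. The pyrrole comparison adds no size, as an at least 1.1-fold lower number from compound 1 to compound 4 (0.07 log units; that floor lies within the scatter) rests on a limit: the limit of > 50000 nM in this assay, at which 1 of the 4 values shown sits.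

Still open, on these data alone, is whether the lower number of compound 3 goes with bromo on any aromatic ring or only with bromo on the furan, a question that 4-bromophenyl at this place would separate. Also open, as far as these compounds go, is how an amine or a carboxylic acid in place of the methyl of compound 4 would read in this growth assay.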